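Compound 4: an anilino link in place of a phenoxy

The source may hold more compounds than are shown below. What is called first, only, known or untested is meant among the compounds shown, and "the series" means these compounds.

Of the compounds shown here, three have so far been measured in an assay on isolated protein for inhibition of A disintegrin and metalloproteinase with thrombospondin motifs 5 (Homo sapiens), read by spectrophotometry, with stated times of 10 min and 3 h; on this read-out lower numbers stand for stronger inhibition and higher numbers for weaker inhibition. Compound 1 `O=C(COc1ccc(C(F)(F)F)cc1)NNC(=S)NCc1ccc(-c2ccccc2)cc1` gives 1700 nM. Compound 2 `O=C(COc1cccc(Cl)c1)NNC(=S)NCc1ccc(-c2ccccc2)cc1` gives 2100 nM, and compound 3 `CC(C)(Oc1ccc(Cl)cc1)C(=O)NNC(=S)NCc1ccc(-c2ccccc2)cc1` gives 6900 nM. Compound 2 therefore stands second highest of the three numbers, close to compound 1 and well apart from compound 3, which gives the highest number. Going by the values given here, the only single-site step recorded, a 1.2-fold higher number from compound 1 to compound 2 (0.09 log units; within the scatter), exchanges one substituted phenyl ring for another on the ether oxygen, and the number hardly moves.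

Compound 4 `O=C(CNc1ccc(Cl)cc1)NNC(=S)NCc1ccc(-c2ccccc2)cc1` has not yet been measured. It differs from compound 2 by (4-chlorophenyl)amino in place of 3-chlorophenoxy on a saturated chain carbon bound to a carbonyl carbon; the ring remains but the atom that joins it to the chain changes and a hydrogen-bond donor appears. Among the compounds with values here, no measured step changes that linking atom, so the expectation can rest only on the ring swap from compound 1 to compound 2, which stayed within the scatter. Compound 4 is therefore expected to give about 2500 nM, with a range from 900 nM to 7000 nM. The expected step is a 1.2-fold higher number from compound 2 to compound 4 (0.08 log units; within the scatter), meaning no shift beyond the scatter is anticipated, though the untested change in the linking atom leaves the range wide.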

Compound 4, half-maximal inhibitory concentration: 6300 nM
Compound 4: middle estimate off by 2.5-fold (0.40 log units), on the low side; the range from low to high includes it.
By their numbers in this assay, from the lowest: compounds 1 and 2 (each within the scatter of the next); then compounds 4 and 3 (each within the scatter of the next).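

Placing (4-chlorophenyl)amino where 3-chlorophenoxy stood on a saturated chain carbon bound to a carbonyl carbon gives, in this assay, a 3.0-fold higher number from compound 2 to compound 4 (0.48 log units; beyond the scatter) and so moves the number beyond the scatter, whereas the earlier change of ring alone, a 1.2-fold higher number from compound 1 to compound 2 (0.09 log units; within the scatter), did not. This shows that the group at this place can matter to inhibition, though the step is modest and points toward weaker inhibition. Two things change together, however: the atom joining the ring to the chain goes from oxygen to nitrogen, adding a hydrogen-bond donor, and the chlorine's printed ring position goes from 3 to 4, and nothing available bears on which of these lies behind the rise.

The clearest open question is how (3-chlorophenyl)amino or 4-chlorophenoxy would read at this place, since either would separate the linking atom from the place of the chlorine. Also open, from the compounds shown here alone, is how a sulfur atom, a methylene group or a methyl-bearing nitrogen would compare as the link to the ring.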